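Extending the chain from compound 2 to compound 3

A few compounds are considered here, and "the series" means these few. Any claim that something is new, unique, unknown or untested is made for them only; others in the source may bear on it.

In a functional assay on SW480 cells (Homo sapiens) for antiproliferative activity, read by MTT assay, with a stated time of 48 h (on this read-out lower numbers stand for stronger inhibition and higher numbers for weaker inhibition), compound 1 (`CC(CCO)n1cnc2c(Cl)nc(F)nc21`) gives 16800 nM and compound 2 (`CCCCC(CCO)n1cnc2c(Cl)nc(F)nc21`) gives 13200 nM and so stands level with it within the scatter. Compound 3 (`CCCCCC(CCO)n1cnc2c(Cl)nc(F)nc21`) follows from compound 2 through methyl in place of hydrogen on a saturated chain carbon, five bonds along the chain from an aromatic nitrogen and, cut one bond further out, reads propyl to butyl. For the measured compounds named here, the one measured step on this chain is a 1.3-fold lower number from compound 1 to compound 2 (0.10 log units; within the scatter) and it stayed within the scatter, so no real shift is expected here. The estimated step of a 1.1-fold lower number from compound 2 to compound 3 (0.06 log units; within the scatter) should likewise stay within the scatter. Compound 3 is expected near 11500 nM with a likely range from 6000 nM to 21000 nM in this measurement.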

Compound 3, half-maximal inhibitory concentration: 7440 nM
For compound 3 the middle estimate is 1.5-fold (0.19 log units) above the measured one; measured number inside the range.
By their numbers in this assay, from the lowest: compounds 3, 2 and 1 (each within the scatter of the next, the first and the last beyond it).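

The added methyl alone gives a 1.8-fold lower number from compound 2 to compound 3 (0.25 log units; within the scatter), so this single change cannot be told apart from repeat-measurement noise. Across the wider change, however, butyl in place of hydrogen gives a 2.3-fold lower number from compound 1 to compound 3 (0.35 log units; beyond the scatter), the first step in this set to clear the scatter, though only modestly. Nothing available here explains this shift.

Going by these compounds, whether a longer chain would continue this trend, level off or reverse it remains open. So does the question of whether an amine at the same place would be tolerated.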